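Sulfonyl aryl swap on the trihydroxyphenyl enone series

This account rests on a few compounds, and the source may have more. Where it says the series, first, only, none or still open, it means among the compounds named here.

Measured compounds:
compound 1 `O=C(/C(=C\c1c(O)cc(O)cc1O)S(=O)(=O)c1ccccc1Br)c1ccc(Cl)cc1` — 50000 nM
compound 2 `Cc1cc(C)cc(/C=C(\C(=O)c2ccc(Cl)cc2)S(=O)(=O)c2ccc(Br)cc2)c1` — 10000 nM
compound 3 `Cc1ccc(CS/C(=C/c2cc(Cl)cc(Cl)c2)C(=O)c2ccc(Cl)cc2)cc1` — 10000 nM

In a functional assay on DU-145 cells (Homo sapiens) for inhibition, read by trypan blue exclusion, with a stated time of 96 h (a lower number here means a stronger inhibitor of growth, a higher number a weaker inhibitor of growth), compound 1 gives 50000 nM, the highest of the three numbers. Compound 2 and compound 3 each sit at a lower number than compound 1, and both gaps lie beyond the scatter. Among the measured compounds shown here, no two measured compounds differ in a single place, so no measured step exists within the set.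

Compound 4 `Cc1ccc(S(=O)(=O)/C(=C/c2c(O)cc(O)cc2O)C(=O)c2ccc(Cl)cc2)cc1` is compound 1 with 4-methylphenyl in place of 2-bromophenyl on a sulfonyl sulfur. For the measured compounds named here, no measured pair isolates this change, so the expectation rests on the spread of the three numbers alone. The step is estimated as a 1.7-fold lower number from compound 1 to compound 4 (0.22 log units; within the scatter), toward a lower number, but of a size not clearly beyond the scatter. Compound 4 is expected to give about 30000 nM, within 8000 nM to 100000 nM.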

Compound 4, concentration for 50% growth inhibition: > 100000 nM
Compound 4 was reported as a limit; the forecaster's own chance of this, stated with the estimate: 25%; at least 3.3-fold (0.52 log units) between middle value and limit.
By their numbers in this assay, from the lowest: compounds 2 and 3 (each within the scatter of the next); then compound 1. At a limit, above all of these: compound 4.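

Compound 4 gives > 100000 nM in this assay, which is a limit of the assay and not a number. Among the compounds shown here, on the sulfonyl sulfur, 4-methylphenyl in place of 2-bromophenyl gives the first single-place step, an at least 2.0-fold higher number from compound 1 to compound 4 (0.30 log units; that floor lies within the scatter), so the swap brings no gain and its true size stays unread. The reading ends at the top of the assay's range: the limit of > 100000 nM in this assay, at which 1 of the 4 values shown sits.

Still open, as far as these compounds go, is how an aminophenyl or a carboxyphenyl on the sulfonyl sulfur would read on the core of compound 1. Also open, from the compounds shown here alone, is whether losing the bromine or gaining the methyl carries the step.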